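This account rests on a few compounds, and the source may have more. Where it says the series, first, only, none or still open, it means among the compounds named here.

Working notes on the series. Compound 2 `COc1cc(C)cc(-c2nn(CC#N)cc2-c2ccnc(-c3ccc(N(C)C)cc3)c2)c1` and compound 1 `Cc1cc(O)cc(-c2nn(CC#N)cc2-c2ccnc(-c3ccc(Oc4ccccc4)cc3)c2)c1` share one core; in a functional assay on NCI-H23 cells (Homo sapiens) for cytotoxicity, read by sulforhodamine B assay, with a stated time of 48 h, tested at 0.01 uM (a higher number here means a weaker effect of the compound at the concentration tested, a lower number a stronger effect), compound 2 gives 97%, and compound 1 gives 93%. Compound 2 stands level with compound 1, the gap between them within the scatter, so neither is set apart on these numbers. Compound 3 `Cc1cc(O)cc(-c2nn(CC#N)cc2-c2ccnc(-c3ccc(N(C)C)cc3)c2)c1` is compound 2 with hydrogen in place of methyl on an oxygen on an aromatic ring. Within the data shown here, no step between measured compounds bears on this change, so the step from compound 2 to compound 3 in this assay is expected to be none beyond the scatter, a number 2 percentage points lower from compound 2 to compound 3 (within the scatter). Compound 3 is estimated at 95%, in the range 85% to 102%.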

Compound 3, a percentage reported as activity, at one concentration (the size of the read-out at that concentration, not a potency): 96%
The estimate for compound 3 lay 1 percentage points below the measured number; the range from low to high includes it.
By their numbers in this assay, from the lowest: compounds 1, 3 and 2 (each within the scatter of the next).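

In this assay, methoxy to hydroxy on the 3-methoxy-5-methylphenyl group gives a number 1 percentage points lower from compound 2 to compound 3 (within the scatter) and so sets neither form of this oxygen apart. Dimethylamino in place of phenoxy on an aromatic carbon, now readable as a single change, gives a number 3 percentage points higher from compound 1 to compound 3 (within the scatter) and likewise separates neither group. Nothing available bears on the reason for these results.
Open, as far as these compounds go, is whether ethoxy in place of methoxy on this oxygen, or a carboxylic acid in place of dimethylamino, would give a number set apart from these compounds.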